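Chloro for Cyano in a Cytotoxic Pair

The source may hold more compounds than are shown below. What is called first, only, known or untested is meant among the compounds shown, and "the series" means these compounds.

Of the compounds shown here, two that share one core have been measured so far. In a functional assay on KG-1 cells (Homo sapiens) for cytotoxicity, read by luminescence and CellTiter-Glo, with a stated time of 3 days (a higher number here means a weaker inhibitor, a lower number a stronger inhibitor), compound 1 (`O=C(Nc1ccc(Cl)cc1Cl)c1ccc2cccnc2c1O`) gives 3560 nM and compound 2 (`N#Cc1ccc(NC(=O)c2ccc3cccnc3c2O)c(C#N)c1`) gives 3770 nM in the same test. Compound 2 thus stands level with compound 1, since the two numbers lie within the usual scatter of repeated measurements.

Compound 3 (`N#Cc1ccc(NC(=O)c2ccc3cccnc3c2O)c(Cl)c1`) has not been measured yet. It differs from compound 2 in one place, with chloro in place of cyano on an aromatic carbon. That carbon is ortho to a large group and meta to a cyano group.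

Among the measured compounds shown here, no measured step between two close relatives exists here, so the size of this change cannot be read from the data. For the measured compounds named here, the only guide is the close agreement of the two known numbers, so no shift beyond the scatter is expected in this assay and no clear direction either. The estimated step is a 1.1-fold lower number from compound 2 to compound 3 (0.03 log units; within the scatter) in this expectation. For compound 3 the estimated value is 3500 nM with an expected range from 1700 nM to 7000 nM in this assay once it is tested.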

Compound 3, half-maximal inhibitory concentration: 3670 nM
Estimate against measurement, compound 3: 1.0-fold (0.02 log units) below; the measured number falls inside the stated range.
By their numbers in this assay, from the lowest: compounds 1, 3 and 2 (each within the scatter of the next).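

Compounds 1 and 2 differ in two places, so their pair could not show what either swap does alone. Compound 3 supplies single-place comparisons in this assay: on the aromatic carbon ortho to a large group and meta to a cyano group, putting chloro in place of cyano gives a 1.0-fold lower number from compound 2 to compound 3 (0.01 log units; within the scatter), even though the swap removes a hydrogen-bond acceptor and a heavy atom, and at the other substituted carbon, putting cyano in place of chloro gives a 1.0-fold higher number from compound 1 to compound 3 (0.01 log units; within the scatter). Both steps lie within the scatter, so this test separates neither swap from repeat measurement, and no information is available on why the three compounds read alike.

These two groups are the only ones shown at these places, so it remains open whether an amine, a carboxylic acid or a longer chain such as n-butyl at the same carbon would also stay within the scatter. Also open, from the compounds shown here alone, is whether a plain hydrogen there would do the same, and whether a swap on the shared core would move the number further than these swaps on the outer ring.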